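The source may hold more compounds than are shown below. What is called first, only, known or untested is meant among the compounds shown, and "the series" means these compounds.

Four compounds share a common core. In an assay on a protein complex for inhibition of CDK8/Cyclin C (Homo sapiens), with a stated time of 1 h (a lower number here means a stronger inhibitor, a higher number a weaker inhibitor), compound 1 `O=C(CCc1ccncc1-c1ccc2ccccc2c1)N1CCOCC1` gives 45.5 nM. Compound 2 `O=C(/C=C/c1ccncc1-c1ccc2ncccc2c1)N1CCOCC1` gives 1590 nM in this assay, the highest of the two numbers recorded; compound 1 sits far lower, a gap beyond the usual scatter. Compound 3 `COC(=O)COc1ccncc1-c1ccc2ccccc2c1` gives "not determined" (no result reported) in this assay, so no number is available for it. Compound 4 `CNC(=O)/C=C/c1ccncc1-c1ccc2ncccc2c1` differs from compound 2 by a single change: methylamino in place of morpholin-4-yl on a carbonyl carbon. Among the measured compounds shown here, no comparable step between measured compounds is available, so the direction of the effect is open. Compound 4 is expected to show a step of a 1.1-fold lower number from compound 2 to compound 4 (0.03 log units; within the scatter) that stays within the scatter. For compound 4 the estimate in this assay is 1500 nM, with an expected range from 500 nM to 5000 nM.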

Compound 4, half-maximal inhibitory concentration: 250 nM
Estimate against measurement, compound 4: 6.0-fold (0.78 log units) above, and the stated range ends above it.
By their numbers in this assay, from the lowest: compound 1; then compound 4; then compound 2.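

In this assay, this first readable step on the carbonyl carbon, methylamino in place of morpholin-4-yl, gives a 6.4-fold lower number from compound 2 to compound 4 (0.80 log units; beyond the scatter). For this pair, the six-membered ring can be given up, and the much smaller group gives the stronger inhibitor. Nothing shown explains the change.

From the compounds shown here alone, whether size or the amide hydrogen matters more remains open; dimethylamino, which has no such hydrogen, or ethylamino at the same place would help separate the two. Also open, going by these compounds, is whether the same change would hold on the core of compound 1.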